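From Isopropyl to Neopentyl on a Ring Nitrogen

The source may hold more compounds than are shown below. What is called first, only, known or untested is meant among the compounds shown, and "the series" means these compounds.

Going by the values given here, in a functional assay (strain AB) with Danio rerio as the target, read by microscopy, with a stated time of 1 h (a lower number here means that less compound is needed, a higher number that more compound is needed for the effect), compound 1 (`CC(C)[N+]1(C)CCc2c(sc(NC(=O)Nc3ccc(Cl)cc3)c2C(N)=O)C1`) gives 960 nM as its half-maximal effective concentration, the lower of the two numbers so far. In this assay compound 2 (`CCN1CCc2sc(NC(=O)Nc3ccc(Cl)cc3)c(C(N)=O)c2CC1`) gives 5800 nM and so needs more compound, a gap beyond the usual scatter. The next compound, compound 3 (`CC(C)(C)C[N+]1(C)CCc2c(sc(NC(=O)Nc3ccc(Cl)cc3)c2C(N)=O)C1`), is compound 1 with neopentyl in place of isopropyl on an amine nitrogen in a ring. Both groups are carbon only and have no ring. Among the compounds with values here, no measured pair shows what a change at this nitrogen does, so the expectation starts from compound 1 at 960 nM and foresees no move beyond the scatter in either direction. The estimated step is a 1.1-fold higher number from compound 1 to compound 3 (0.06 log units; within the scatter) and stays within that scatter. Compound 3 is expected at 1100 nM with an estimated range of 350 nM to 3500 nM in this measurement.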

Compound 3, half-maximal effective concentration: 290 nM
Compound 3: the middle estimate sits 3.8-fold (0.58 log units) above what was measured; measured number below the stated range.
By their numbers in this assay, from the lowest: compound 3; then compound 1; then compound 2.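

At the ring nitrogen, the step of a 3.3-fold lower number from compound 1 to compound 3 (0.52 log units; beyond the scatter) in this assay shows that this position is sensitive to which carbon-only group it carries. The change replaces isopropyl, with 3 heavy atoms, by neopentyl, with 5 heavy atoms, and neither group has a ring or any hydrogen-bond donor or acceptor, so the larger of these two groups needs less compound for the effect. Nothing available explains why this single swap lowers the number.

One step cannot show whether the number keeps falling as the carbon group grows, or whether the neopentyl shape itself matters. A longer straight chain such as n-pentyl, a ring-bearing group such as benzyl, or a chain carrying a hydroxyl group at this nitrogen could help separate those possibilities.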